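Replacing a Difluoroethylphenyl with a Dimethoxyphenyl: Expected Inhibition

A few compounds are considered here, and "the series" means these few. Any claim that something is new, unique, unknown or untested is made for them only; others in the source may bear on it.

Measured compounds:
compound 1 `Cc1cccc(N2C(=O)CSC2c2cccc(C(=O)NCCCCc3ccccc3)c2)c1` gives 39%
compound 2 `CC(F)(F)c1cccc(N2C(=O)CSC2c2cccc(C(=O)NCCCCc3ccccc3)c2)c1` gives 24%

Both compounds were tested in a functional assay on U2OS cells (Homo sapiens) for inhibition, read by CCK-8 assay, with a stated time of 72 h, tested at 1 uM; a higher number here means more inhibition at the concentration tested (going by the name of the read-out), a lower number less inhibition. Compound 2 stands lowest of the two numbers; its nearest neighbour is compound 1, and the step of a number 15 percentage points lower from compound 1 to compound 2 (beyond the scatter) lies beyond the scatter, so the number for compound 2 is the lower of the pair.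

Compound 3 `COc1ccc(N2C(=O)CSC2c2cccc(C(=O)NCCCCc3ccccc3)c2)c(OC)c1` is not yet measured. Its difference from compound 2 is a group of 10 heavy atoms (8 carbon, 2 oxygen; one six-membered aromatic ring of carbon only) in place of a group of 10 heavy atoms (8 carbon, 2 fluorine; one six-membered aromatic ring of carbon only), on an amide-type nitrogen in a ring.

For the measured compounds named here, only one measured step exists, the one from compound 1 to compound 2, and it concerns a swap of methyl for 1,1-difluoroethyl at a single aromatic carbon. The change to compound 3 exchanges the whole ring on the amide-type nitrogen, so that step bears on it only loosely: it shows that the group on this nitrogen moves the read-out by a modest amount. The dimethoxyphenyl is new, so no direction can be read from the data. Compound 3 is therefore expected to sit near the middle of the two measured values, with the step of a number 8 percentage points higher from compound 2 to compound 3 (within the scatter) being the estimate, giving compound 3 an expected 32% within 10% to 55%.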

Compound 3, a percentage reported as inhibition, at one concentration (the size of the read-out at that concentration, not a potency): 37%
Estimate against measurement, compound 3: 5 percentage points below, within the range that was stated.
By their numbers in this assay, from the lowest: compound 2; then compounds 3 and 1 (each within the scatter of the next).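

On the amide-type nitrogen of the shared core, 2,4-dimethoxyphenyl in this assay gives a number 13 percentage points higher from compound 2 to compound 3 (beyond the scatter), a step beyond the scatter, so the low number of compound 2 does not hold for every group of 10 heavy atoms at this place. Set against 3-methylphenyl, the same group gives a number 2 percentage points lower from compound 1 to compound 3 (within the scatter), which lies within the scatter, so these two groups cannot be told apart by this read-out, and among the three compounds only compound 2 stands apart from the others. No measurement at hand explains why the group carrying 1,1-difluoroethyl differs from the other two.

The compounds shown leave open whether both methoxy groups are needed for this number, a question that a 2-methoxyphenyl or a 4-methoxyphenyl group on the same nitrogen would address. They also leave open how an unsubstituted phenyl ring, or a phenyl ring carrying an amine or a carboxylic acid, would read at this place.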